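This account rests on a few compounds, and the source may have more. Where it says the series, first, only, none or still open, it means among the compounds named here.

Compound 2 `CNC(=O)c1c(-c2ccc(F)cc2)oc2cc(N(c3ccc(B(O)O)c(Cl)c3)S(C)(=O)=O)c(C3CC3)cc12` is the reference point of this account. In an ADME assay on the whole organism (Rattus norvegicus) for pharmacokinetics, read by LC-MS, at a dose of 1 mg/kg by the intravenous route (on this read-out lower numbers stand for slow clearance and higher numbers for fast clearance), compound 2 gives 5.1 mL/min/kg, the second highest of the three numbers measured. Compound 3 `CNC(=O)c1c(-c2ccc(F)cc2)oc2cc(-n3ncnc3-c3ccc(B(O)O)c(F)c3)c(C3CC3)cc12`, which carries a different linking group on the shared core, gives 4.5 mL/min/kg in this assay, a number within the scatter of compound 2. Within the data shown here, compound 1 `CNC(=O)c1c(-c2ccc(F)cc2)oc2cc(N(Cc3ccc(B(O)O)c(F)c3)S(C)(=O)=O)c(C3CC3)cc12` gives 29 mL/min/kg in this assay, and the step of a 5.7-fold lower number from compound 1 to compound 2 (0.75 log units; beyond the scatter) is the only measured change on the sulfonamide nitrogen, and therefore the only one that bears directly on what follows.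

Compound 4 `CNC(=O)c1c(-c2ccc(F)cc2)oc2cc(N(C3CCc4c(B(O)O)cccc43)S(C)(=O)=O)c(C3CC3)cc12` differs from compound 2 in that same place: a group of 12 heavy atoms (9 carbon, 1 boron, 2 oxygen; one five-membered non-aromatic ring of carbon only, one six-membered aromatic ring of carbon only) in place of a group of 10 heavy atoms (6 carbon, 1 boron, 2 oxygen, 1 chlorine; one six-membered aromatic ring of carbon only), on a sulfonamide nitrogen. Among the measured compounds shown here, the one comparable step moved clearance by a modest amount when the group on the sulfonamide nitrogen was exchanged, so the expectation is that a further exchange there can move the number again. Since compound 2 sits at the slower end together with compound 3, and only compound 1 shows a faster clearance, the estimate for compound 4 is a step of a 2.4-fold higher number from compound 2 to compound 4 (0.37 log units; beyond the scatter) upward, of a size that may or may not clear the scatter. Compound 4 is expected to give 12 mL/min/kg in this assay, within a range from 5 mL/min/kg to 30 mL/min/kg.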

Compound 4, clearance: 69 mL/min/kg
For compound 4 the middle estimate is 5.8-fold (0.76 log units) below the measured one; the measured number lies above the stated range.
By their numbers in this assay, from the lowest: compounds 3 and 2 (each within the scatter of the next); then compound 1; then compound 4.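

In this assay, among these compounds, the group on the sulfonamide nitrogen reaches much further than the one earlier step could show: the group with one five-membered non-aromatic ring of carbon only and one six-membered aromatic ring of carbon only gives a 14-fold higher number from compound 2 to compound 4 (1.13 log units; beyond the scatter), and it also gives a 2.4-fold higher number from compound 1 to compound 4 (0.38 log units; beyond the scatter). The three compounds that vary at this nitrogen now stand at three separate levels, each beyond the scatter of the others, with compound 2 lowest, compound 1 in the middle and compound 4 highest, so the earlier step did not mark the top of what an exchange here can do. Nothing available explains the size of these steps.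

The entering group differs from both groups it replaces in its ring count and its carbon count and also carries no halogen, so the compounds shown do not separate which of these differences goes with the higher number. As far as these compounds go, it also remains open where a group on this nitrogen bearing an amine or a carboxylic acid would fall in this assay relative to compound 2 and compound 4.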